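A few compounds are considered here, and "the series" means these few. Any claim that something is new, unique, unknown or untested is made for them only; others in the source may bear on it.

In a functional assay on HepG2 cells (Homo sapiens) for inhibition, read by MTT assay, with a stated time of 48 h (a lower number here means a stronger inhibitor, a higher number a weaker inhibitor), compound 3 `Clc1ccc(CSc2nnc(-c3ccncc3)n2-c2ccccc2)cc1` gives 16900 nM. Compound 2 `Clc1cccc(CSc2nnc(-c3ccncc3)n2-c2ccccc2)c1` gives 11200 nM, and a 1.5-fold higher number from compound 2 to compound 3 (0.18 log units; within the scatter) places the two level with each other. Compound 1 `Fc1ccccc1CSc1nnc(-c2ccncc2)n1-c1ccccc1` is reported only as a limit, > 50000 nM. Compound 4 `c1ccc(CSc2nnc(-c3ccncc3)n2-c2ccccc2)cc1` differs from compound 3 by hydrogen in place of chloro on an aromatic carbon, with hydrogen in place of chloro on an aromatic carbon, para to a large group. Among the measured compounds shown here, no measured step removes the chloro. The nearest evidence is an at least 4.4-fold lower number from compound 1 to compound 2 (0.64 log units; beyond the scatter) and an at least 2.9-fold lower number from compound 1 to compound 3 (0.47 log units; beyond the scatter), though both also replace 2-fluorophenyl, so any expected drift is slight and towards a weaker inhibitor. The expected change is a 1.5-fold higher number from compound 3 to compound 4 (0.17 log units; within the scatter), and no step beyond the scatter is expected. For compound 4 the estimated value is 25000 nM, with an expected range of 10000 nM to 50000 nM.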

Compound 4, half-maximal inhibitory concentration: 12900 nM
Compound 4: middle estimate off by 1.9-fold (0.29 log units), on the high side, within the range that was stated.
By their numbers in this assay, from the lowest: compounds 2, 4 and 3 (each within the scatter of the next). At a limit, above all of these: compound 1.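

In this assay, taking the chloro off leaves the number level: a 1.3-fold lower number from compound 3 to compound 4 (0.12 log units; within the scatter), and a 1.2-fold higher number from compound 2 to compound 4 (0.06 log units; within the scatter), so a chloro on this ring is not needed for the activity seen here. Hydrogen in place of fluoro gives an at least 3.8-fold lower number from compound 1 to compound 4 (0.58 log units; beyond the scatter), which leaves the 2-fluorophenyl compound alone apart from the other three. Compound 1 is known only as a limit: the limit of > 50000 nM in this assay, at which 1 of the 4 values shown sits.

The compounds shown leave open whether 4-fluorophenyl would follow 2-fluorophenyl or the chlorophenyl compounds. They also leave open whether an amine, a carboxylic acid or a methoxy group on this ring would move the number beyond the scatter.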